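The source may hold more compounds than are shown below. What is called first, only, known or untested is meant among the compounds shown, and "the series" means these compounds.

Measured so far:
Compound 1 `C/C(=N/NC(=O)Nc1nc(-c2ccc(C)cc2)cc(-c2ccc(F)cc2)n1)c1ccc(Cl)cc1`: in a functional assay on the whole organism (strain Albino) with Mus musculus as the target, with a stated time of 0.5 h (on this read-out lower numbers stand for an effect already at smaller amounts and higher numbers for an effect only at larger amounts of compound), compound 1 gives 30 mg/kg.
Compound 2 `C/C(=N/NC(=O)Nc1nc(-c2ccc(C)cc2)cc(-c2ccc(Cl)cc2)n1)c1ccc([N+](=O)[O-])cc1`: in this assay compound 2 gives 100 mg/kg.

Among these two numbers compound 2 stands at the highest; its nearest neighbour is compound 1, whose number is lower by a margin that lies beyond the usual scatter of this kind of measurement. No pair of these compounds differs in only one place, so no single step can be read from them; what compound 1 and compound 2 show is merely that their two values lie apart.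

Compound 3 `C/C(=N/NC(=O)Nc1nc(-c2ccc(C)cc2)cc(-c2ccc(Cl)cc2)n1)c1ccc(Cl)cc1` has not yet been measured. Compared with compound 2, the change is chloro in place of nitro on an aromatic carbon, para to a large group; cut one bond further out, it reads 4-nitrophenyl to 4-chlorophenyl. With this change compound 3 carries the same 4-chlorophenyl group that compound 1 carries, and compound 1 gives 30 mg/kg, whereas compound 2 gives 100 mg/kg. On that basis the step from compound 2 to compound 3 is expected to run toward a lower number, by about a 2.5-fold lower number from compound 2 to compound 3 (0.40 log units; beyond the scatter), somewhat beyond the scatter. For compound 3 the estimate in this assay is 40 mg/kg, with a range from 15 mg/kg to 110 mg/kg.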

Compound 3, dose for half-maximal effect: 30 mg/kg
Beside the measured number, compound 3's estimate is 1.3-fold (0.12 log units) above it; measured number inside the range.
By their numbers in this assay, from the lowest: compounds 1 and 3 (each within the scatter of the next); then compound 2.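

In this assay, chloro in place of nitro on an aromatic carbon, para to a large group, gives a 3.3-fold lower number from compound 2 to compound 3 (0.52 log units; beyond the scatter). Among these compounds, this is the first single-place step, and it shows that the choice of group at this position registers beyond the scatter, though the step is modest. The second step, from fluoro to chloro at another place on the core, gives no change at the digits printed from compound 1 to compound 3 (within the scatter), so this assay does not separate those two groups there, and nothing measured on hand explains either step.

The compounds shown leave open whether the higher number of compound 2 is particular to nitro or would also appear with a nitrile, an amine or a methoxy group at the same position, or with plain hydrogen there. They also leave open whether the step from nitro to chloro would keep its size with fluoro rather than chloro at the other place, since nitro appears here only alongside chloro.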